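Swapping a hydroxyl position on a pyridine-linked phenyl ring

This account rests on a few compounds, and the source may have more. Where it says the series, first, only, none or still open, it means among the compounds named here.

Four compounds sharing a closely related core are compared in a functional assay on HeLa cells (Homo sapiens) for cytotoxicity, read by CCK-8 assay; on this read-out lower numbers stand for stronger inhibition and higher numbers for weaker inhibition. Compound 1 `Oc1cccc(-c2cc(-c3ccco3)cc(-c3ccccc3O)n2)c1` carries a 3-hydroxyphenyl group, a 2-hydroxyphenyl group and a furan-2-yl group on its core. In this assay compound 1 reaches only the limit of the assay, > 50000 nM, and not a number. Compound 2 `Oc1ccc(-c2cc(-c3ccco3)cc(-c3ccccc3O)n2)cc1` differs from compound 1 by 4-hydroxyphenyl in place of 3-hydroxyphenyl on an aromatic carbon; on this assay compound 2 also stops at the limit, > 50000 nM, which is again not a number. The step that the two limits leave unreadable from compound 1 to compound 2 therefore cannot be sized, the reason being (the limit of > 50000 nM in this assay, at which 2 of the 3 values shown sit).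

Compound 3 `Oc1cccc(-c2cc(-c3ccoc3)cc(-c3cccc(O)c3)n2)c1` has a different core, carrying two 3-hydroxyphenyl groups and a furan-3-yl group; how this core differs from that of compound 1 is not broken down here. In this assay, among the compounds with values here, compound 3 gives 4630 nM, the only true number in the set.

Compound 4 `Oc1ccc(-c2cc(-c3ccoc3)cc(-c3cccc(O)c3)n2)cc1`, not yet measured, differs from compound 3 by 4-hydroxyphenyl in place of 3-hydroxyphenyl on an aromatic carbon. Within the data shown here, this is the same kind of change as the one from compound 1 to compound 2, but the surroundings differ: there the place is meta to a 2-hydroxyphenyl group and meta to a furan-2-yl group, here it is meta to a 3-hydroxyphenyl group and meta to a furan-3-yl group. Since the measured pair gives no readable size, the step from compound 3 to compound 4 is expected to be about a 1.9-fold higher number from compound 3 to compound 4 (0.29 log units; within the scatter), a modest weakening with wide uncertainty. Compound 4 is thus estimated at 9000 nM, with a plausible range from 2500 nM to 40000 nM.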

Compound 4, half-maximal inhibitory concentration: 3310 nM
Compound 4: middle estimate off by 2.7-fold (0.43 log units), on the high side; measured number inside the range.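

In this assay, putting a 4-hydroxyphenyl group in place of a 3-hydroxyphenyl group on the core of compound 3 gives a 1.4-fold lower number from compound 3 to compound 4 (0.15 log units; within the scatter), so on this core repeated measurements could not tell the two hydroxyl positions apart. The same change on the core of compound 1 offers nothing to set beside this result, because compound 1 and compound 2 both stop at a limit rather than a number, and the step between them cannot be read: the limit of > 50000 nM in this assay, at which 2 of the 4 values shown sit. This leaves a single readable pair on a single core, which shows that the change makes no measurable difference there but does not show that the change behaves the same way on the core of compound 1.

The compounds shown leave open how the result would look if the hydroxyl on this ring gave way to a different group, such as a methoxy group, an amine or a carboxylic acid. Within the data shown here, they also include no pair that differs only in the furan-2-yl group or only in the 2-hydroxyphenyl group, so the separate contribution of each to the difference between the two cores remains unknown.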